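This account rests on a few compounds, and the source may have more. Where it says the series, first, only, none or still open, it means among the compounds named here.

Among the compounds with values here, in an ADME assay on Huh-7 cells (Homo sapiens) for cytotoxicity, read by a luciferase reporter and WST assay, with a stated time of 3 days (a lower number here means that less compound is tolerated, a higher number that more compound is tolerated), compound 1 `COc1ccc(-c2cc(NO)c(C(=O)Nc3ccccc3)c(=O)o2)cc1` gives 16200 nM, the only true number among the three compounds measured so far. Compound 2 `O=C(Nc1ccc(O)cc1)c1c(NO)cc(-c2ccccc2)oc1=O` reads > 20000 nM, which is a limit of the assay and not a number. Compound 3 `Cc1ccc(NC(=O)c2c(NO)cc(-c3ccc(Cl)cc3)oc2=O)cc1` reads > 20000 nM, which is also a limit. The set is thus marked by the limit of > 20000 nM in this assay, at which 2 of the 3 values shown sit, and compound 2 stands at that limit without a value of its own.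

Compound 4 `CC(C)NC(=O)c1c(NO)cc(-c2ccccc2)oc1=O` carries isopropyl in place of 4-hydroxyphenyl on an amide-type nitrogen. Within the data shown here, no pair of measured compounds differs in one place, and none of them carries isopropyl there, so the data offer no direct guide to this change. In this assay, the expectation is therefore no change beyond the scatter. The expected size of the change, a number no higher from compound 2 to compound 4 (the limit leaves the size open), is correspondingly small, and a reading at the limit would be no surprise. For compound 4, the estimated value is 20000 nM, with an expected range of 9000 nM to 40000 nM.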

Compound 4, half-maximal cytotoxic concentration: > 20000 nM
Compound 4 ended at the assay's limit; the forecaster's own chance of this, stated with the estimate: 60%; the middle value lies on the limit itself.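

Compound 2 and compound 4 both stand at the same limit of this assay, which is not a number, and no step can be read between them: the limit of > 20000 nM in this assay, at which 3 of the 4 values shown sit. The compounds shown leave open how far either compound lies beyond that limit, and whether isopropyl and 4-hydroxyphenyl differ here at all.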